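Cyclopropylmethyl in Place of Neopentyl on the Ring Amine

The compounds below may be only part of what the source reports. "The series", "measured", "known", "first", "only" and "open" are said of these compounds alone.

Of the compounds shown here, two have been measured in an assay on HEK293 cells for binding affinity to 5-hydroxytryptamine receptor 7 (Homo sapiens), read by radioligand binding; a lower number here means a stronger inhibitor, a higher number a weaker inhibitor. Compound 1 `CC(C)N1CCCN(CCn2ccc3ccc(Br)cc32)CC1` gives 14 nM. Compound 2 `CC(C)(C)CN1CCCN(CCn2ccc3ccc(Br)cc32)CC1` gives 163 nM, the highest of the two numbers; its nearest neighbour is compound 1, and the step of a 12-fold higher number from compound 1 to compound 2 (1.07 log units; beyond the scatter) is large and beyond the scatter.

Compound 3 `Brc1ccc2ccn(CCN3CCCN(CC4CC4)CC3)c2c1` differs from compound 2 in one place: cyclopropyl in place of tert-butyl on a saturated chain carbon bound to an amine nitrogen in a ring. For the measured compounds named here, the only measured step that bears on this change is a 12-fold higher number from compound 1 to compound 2 (1.07 log units; beyond the scatter), where a larger branched group on the same ring amine nitrogen gave a much higher number. Going by the values given here, compound 3 carries a group that is smaller than the one in compound 2, so compound 3 is expected to give a number between those of compound 1 and compound 2, with the step of a 5.4-fold lower number from compound 2 to compound 3 (0.74 log units; beyond the scatter) estimated to be beyond the scatter. The estimate for compound 3 in this assay is 30 nM, with a range from 10 nM to 90 nM.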

Compound 3, inhibition constant: 9 nM
Compound 3: middle estimate off by 3.3-fold (0.52 log units), on the high side; measured number below the stated range.
By their numbers in this assay, from the lowest: compounds 3 and 1 (each within the scatter of the next); then compound 2.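

In this assay, cyclopropyl in place of tert-butyl on a saturated chain carbon bound to an amine nitrogen in a ring gives an 18-fold lower number from compound 2 to compound 3 (1.26 log units; beyond the scatter), although the entering group has 3 heavy atoms and the leaving group 4. The high number of compound 2 therefore goes with neopentyl in particular, not with every group of more than isopropyl's reach on this nitrogen. Cyclopropylmethyl in place of isopropyl gives a 1.6-fold lower number from compound 1 to compound 3 (0.19 log units; within the scatter), so these two groups cannot be told apart here, and no measurement offers an explanation for the large step.

The compounds shown leave open whether a cyclobutylmethyl group or a straight propyl chain on this nitrogen would stay level with compound 1 and compound 3 or approach compound 2. They also leave open whether a hydroxyethyl group would be tolerated at this position.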